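A Methoxy in Place of Ethyl: Compound 1 to Compound 4

This account rests on a few compounds, and the source may have more. Where it says the series, first, only, none or still open, it means among the compounds named here.

Measured compounds:
compound 1, `CCc1cnc(N2CCC(c3coc4c(N5CCc6cc(S(C)(=O)=O)ccc65)ncnc34)CC2)nc1`, 41 nM
compound 2, `CC(C)(C)OC(=O)N1CCC(c2coc3c(Nc4ccc(S(C)(=O)=O)cc4F)ncnc23)CC1`, 129 nM
compound 3, `CC(C)(C)OC(=O)N1CCC(c2csc3c(Nc4ccc(S(C)(=O)=O)cc4F)ncnc23)CC1`, 79 nM

In a functional assay on cells for agonist activity at Glucose-dependent insulinotropic receptor (Homo sapiens), read by a luciferase reporter, with a stated time of 4 h (on this read-out higher numbers stand for an effect only at larger amounts of compound and lower numbers for an effect already at smaller amounts), compound 1 gives 41 nM, the lowest of the three numbers. Its nearest neighbour is compound 3 with 79 nM, a gap that stays within the usual scatter, so the two cannot be ranked against each other. Compound 2 with 129 nM lies beyond the scatter from compound 1. Going by the values given here, compound 2 and compound 3 share an amine on the core that differs from the one carried by compound 1, and no pair among the three differs in a single place, so none of these numbers isolates one change.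

The untested compound 4 is `COc1cnc(N2CCC(c3coc4c(N5CCc6cc(S(C)(=O)=O)ccc65)ncnc34)CC2)nc1`. It differs from compound 1 by methoxy in place of ethyl on an aromatic carbon. Among the compounds with values here, no measured pair shows this exchange, so there is no step to lean on. Given compound 1 at 41 nM, the exchange of one small group for another of the same size is expected to move this assay little, and no step beyond the scatter is expected in either direction. Compound 4 is therefore estimated at 50 nM, with a range from 18 nM to 140 nM, which means an expected step of a 1.2-fold higher number from compound 1 to compound 4 (0.09 log units; within the scatter).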

Compound 4, half-maximal effective concentration: 310 nM
Estimate against measurement, compound 4: 6.2-fold (0.79 log units) below; the whole stated range lies below it.
By their numbers in this assay, from the lowest: compounds 1, 3 and 2 (each within the scatter of the next, the first and the last beyond it); then compound 4.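

In this assay, the change from 5-ethylpyrimidin-2-yl to 5-methoxypyrimidin-2-yl gives a 7.6-fold higher number from compound 1 to compound 4 (0.88 log units; beyond the scatter), the first step among these compounds that isolates a single place, and it shows that this aromatic carbon does not tolerate every group of this size alike. Ethyl and methoxy have the same count of heavy atoms, so that count alone does not set the read-out here; the entering group differs by one oxygen in place of a carbon and by one hydrogen-bond acceptor, and the number still moves beyond the scatter. Nothing available here accounts for a step of this size.

From the compounds shown here alone, this single pair cannot separate the role of the oxygen from that of the methoxy group as a whole, and it remains open whether a methyl, a propyl or a chlorine on this carbon would stay close to compound 1 or move as compound 4 does. Going by these compounds, it is also open whether the same exchange would have a similar effect with a different amine on the shared core.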